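A few compounds are considered here, and "the series" means these few. Any claim that something is new, unique, unknown or untested is made for them only; others in the source may bear on it.

Compounds measured in a functional assay on T84 cells (Homo sapiens) for antiproliferative activity, read by MTT assay, with a stated time of 72 h; a higher number here means a weaker inhibitor, a lower number a stronger inhibitor:
compound 1 `COc1ccc(/C=C2\CCC/C(=C\c3cc(OC)c(OC)c(OC)c3)C2=O)cc1OC` — 1900 nM
compound 2 `COc1cc(/C=C2\CCC/C(=C\c3ccccc3F)C2=O)cc(OC)c1OC` — 2200 nM

Compound 2 and compound 1 lie within the scatter of each other: a 1.2-fold higher number from compound 1 to compound 2 (0.06 log units; within the scatter). Neither can be called the stronger inhibitor on these two numbers. Compound 3 `COc1cc(/C=C2\CCC/C(=C\c3ccc(F)c(F)c3)C2=O)cc(OC)c1OC` differs from compound 2 in one place: 3,4-difluorophenyl in place of 2-fluorophenyl on a double-bonded chain carbon bound to a double-bonded ring carbon. Among the compounds with values here, the only measured step, a 1.2-fold higher number from compound 1 to compound 2 (0.06 log units; within the scatter), also exchanged the group at this place and stayed within the scatter, so no step beyond the scatter is expected here either: no change at the digits printed from compound 2 to compound 3 (within the scatter). In this assay compound 3 is therefore expected to give about 2200 nM, most likely between 900 nM and 5500 nM.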

Compound 3, half-maximal inhibitory concentration: 3500 nM
Beside the measured number, compound 3's estimate is 1.6-fold (0.20 log units) below it; measured number inside the range.
By their numbers in this assay, from the lowest: compounds 1, 2 and 3 (each within the scatter of the next).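

Three different phenyl groups have now stood at this place, on a double-bonded chain carbon bound to a double-bonded ring carbon, and in this assay every step between them lies within the scatter (a 1.6-fold higher number from compound 2 to compound 3 (0.20 log units; within the scatter); a 1.8-fold higher number from compound 1 to compound 3 (0.27 log units; within the scatter)). Thus 3,4-difluorophenyl, 2-fluorophenyl and 3,4-dimethoxyphenyl cannot be told apart here. Nothing available gives a reason for these numbers.

Open, on these data alone, is whether a group without a phenyl ring, such as an amine, a carboxylic acid or a longer chain, would give a step beyond the scatter at this place.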